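Swapping the heteroaryl arm in a sulfonyl hydroxyguanidine series

The source may report more compounds than this note shows. Statements on the series, on what has been measured and on what is new or still open speak of the compounds shown alone.

Measured compounds:
Compound 1, `COc1cc(CSc2cc(Cl)c(-c3nnc(-c4ccc(Cl)cc4)s3)cc2S(=O)(=O)NC(=N)NO)cc(OC)c1OC`: 8910 nM
Compound 2, `N=C(NO)NS(=O)(=O)c1cc(-c2nnc(-c3ccc(Cl)cc3)s2)c(Cl)cc1SCc1ccccc1`: 1670 nM

Compound 1 was tested in a functional assay on NCI-H522 cells (Homo sapiens) (on this read-out lower numbers stand for stronger inhibition of growth and higher numbers for weaker inhibition of growth), and gives 8910 nM, the highest of the two numbers shown. Its neighbour compound 2 differs only on the saturated chain carbon bound to a sulfur, and the change was a 5.3-fold lower number from compound 1 to compound 2 (0.73 log units; beyond the scatter).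

Compound 3, `COc1cc(CSc2cc(Cl)c(-c3nc(-c4ccccc4)no3)cc2S(=O)(=O)NC(=N)NO)cc(OC)c1OC`, has not been measured. It differs from compound 1 at another place entirely: 3-phenyl-1,2,4-oxadiazol-5-yl in place of 5-(4-chlorophenyl)-1,3,4-thiadiazol-2-yl on an aromatic carbon, on an aromatic carbon ortho to a chloro group and para to a large group. Among the compounds with values here, no measured step touches this part of the shared core, so the single step from compound 1 to compound 2 says nothing about it. With no evidence either way, compound 3 is expected to stay near compound 1, with a step of a 1.1-fold lower number from compound 1 to compound 3 (0.05 log units; within the scatter) not beyond the scatter. The estimate for compound 3 is 8000 nM, within 2500 nM to 25000 nM.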

Compound 3, concentration for 50% growth inhibition: 3800 nM
Beside the measured number, compound 3's estimate is 2.1-fold (0.32 log units) above it; measured number inside the range.
By their numbers in this assay, from the lowest: compound 2; then compound 3; then compound 1.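

The aromatic carbon ortho to a chloro group, which the earlier step left untouched, also matters in this assay: 3-phenyl-1,2,4-oxadiazol-5-yl in place of 5-(4-chlorophenyl)-1,3,4-thiadiazol-2-yl gives a 2.3-fold lower number from compound 1 to compound 3 (0.37 log units; beyond the scatter). Growth inhibition in compound 3 therefore survives an exchange of the whole arm, and with the 3,4,5-trimethoxyphenyl group held in place, the number moves beyond the scatter. No measurement on hand accounts for this step.

This one change alters both the five-membered ring and the chlorine on the phenyl ring, so the two cannot be told apart here; a 3-(4-chlorophenyl)-1,2,4-oxadiazol-5-yl arm would separate them. Also open, from the compounds shown here alone, is how this arm behaves with phenyl in place of 3,4,5-trimethoxyphenyl on the saturated chain carbon bound to a sulfur.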